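The source may hold more compounds than are shown below. What is called first, only, known or untested is meant among the compounds shown, and "the series" means these compounds.

Among the compounds with values here, compound 2 `CC1CCN(c2nc(C(F)(F)F)ccc2CNC(=O)C(c2ccc(F)cc2)c2ccc(NS(C)(=O)=O)c(F)c2)CC1` gives 3.4 nM in an assay on CHO cells for antagonist activity at transient receptor potential cation channel subfamily V member 1 (Homo sapiens), read by FLIPR (on this read-out higher numbers stand for weaker inhibition and lower numbers for stronger inhibition), the lowest of the three numbers measured so far. Compound 3 `CS(=O)(=O)Nc1ccc(C(C(=O)NCc2ccc(C(F)(F)F)nc2SC2CCCCC2)c2ccc(F)cc2)cc1F` gives 37.6 nM, and compound 1 `CC1CCN(c2nc(C(F)(F)F)ccc2CNC(=O)C(c2ccc(NS(C)(=O)=O)c(F)c2)C2CCCC2)CC1` gives 88.7 nM. Compound 4 `CC1CCN(c2nc(C(F)(F)F)ccc2CNC(=O)C(Cc2ccc(F)cc2)c2ccc(NS(C)(=O)=O)c(F)c2)CC1` carries 4-fluorobenzyl in place of 4-fluorophenyl on a saturated chain carbon bound to an aromatic carbon and a carbonyl carbon. Within the data shown here, the one measured step at this saturated chain carbon, a 26-fold lower number from compound 1 to compound 2 (1.42 log units; beyond the scatter), was large, so this assay responds strongly to what sits there; the other step, an 11-fold higher number from compound 2 to compound 3 (1.04 log units; beyond the scatter), concerns the aromatic carbon and bears less on the present change. Among the measured compounds shown here, no measured compound shows a 4-fluorobenzyl at this carbon, so a moderate loss is expected for compound 4, a 4.4-fold higher number from compound 2 to compound 4 (0.64 log units; beyond the scatter). Compound 4 is therefore estimated at 15 nM, with a range from 4 nM to 60 nM.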

Compound 4, inhibition constant: 49.3 nM
Compound 4: the middle estimate sits 3.3-fold (0.52 log units) below what was measured; the range from low to high includes it.
By their numbers in this assay, from the lowest: compound 2; then compounds 3, 4 and 1 (each within the scatter of the next, the first and the last beyond it).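

Replacing 4-fluorophenyl with 4-fluorobenzyl on this saturated chain carbon costs much in this assay (a 15-fold higher number from compound 2 to compound 4 (1.16 log units; beyond the scatter)), so keeping a fluorinated aromatic ring in the group does not preserve the low number. Compared with cyclopentyl, 4-fluorobenzyl brings no change beyond the scatter (a 1.8-fold lower number from compound 1 to compound 4 (0.26 log units; within the scatter)), and among these three groups only 4-fluorophenyl gives the low number. The compounds offer no evidence explaining this difference.

Going by these compounds, how an unsubstituted phenyl, a pyridyl ring or a longer 2-(4-fluorophenyl)ethyl chain would read at this carbon remains open. So does whether the same change would cost as much with cyclohexylsulfanyl in place of 4-methylpiperidin-1-yl.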